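A few compounds are considered here, and "the series" means these few. Any claim that something is new, unique, unknown or untested is made for them only; others in the source may bear on it.

Compound 1 `COc1ccccc1C1CCN(c2ccn3c(CC4CC4)nnc3c2Cl)CC1` was examined in an ADME assay on a cell-free system (plasma, Homo sapiens) for protein binding; on this read-out higher numbers stand for a larger free fraction and lower numbers for a smaller free fraction. In this assay compound 1 gives < 0.01, which is a limit of the assay and not a number. Compound 2 `COc1c(F)cccc1C1CCN(c2ccn3c(CC4CC4)nnc3c2Cl)CC1` carries fluoro in place of hydrogen on an aromatic carbon. In this assay compound 2 gives < 0.01, again a limit. Compound 3 `COc1c(F)ccc(F)c1C1CCN(c2ccn3c(CC4CC4)nnc3c2Cl)CC1` carries 3,6-difluoro-2-methoxyphenyl in place of 2-methoxyphenyl on a saturated ring carbon. In this assay compound 3 gives < 0.01, also a limit. Because of the limit of < 0.01 in this assay, at which 3 of the 3 values shown sit, the steps a step that the two limits leave unreadable from compound 1 to compound 2, a step that the two limits leave unreadable from compound 1 to compound 3 and a step that the two limits leave unreadable from compound 2 to compound 3 cannot be sized. Compound 4 `COc1cc(F)cc(F)c1C1CCN(c2ccn3c(CC4CC4)nnc3c2Cl)CC1` differs from compound 1 by 2,4-difluoro-6-methoxyphenyl in place of 2-methoxyphenyl on a saturated ring carbon. All three measured steps bear on this change: each puts fluoro onto the same aryl group, and none gave a readable size. Compound 4 is therefore expected to sit at the same limit, the estimated step being a step that the limit leaves unreadable from compound 1 to compound 4. For compound 4 the estimated value in this assay is 0.005, with a range from 0.002 to 0.012.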

Compound 4, unbound fraction: < 0.01
Compound 4 ended at the assay's limit (the forecaster's own chance of this, stated with the estimate: 85%); the middle value does not contradict the limit.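

In this assay no new step can be read between compound 4 and compound 1, compound 2 or compound 3, because all of them stand at one limit: the limit of < 0.01 in this assay, at which 4 of the 4 values shown sit.

The compounds shown leave open how large the unbound fraction of each compound is, and whether fluoro on the methoxyphenyl group alters it at all.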